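The source may hold more compounds than are shown below. What is called first, only, known or untested is meant among the compounds shown, and "the series" means these compounds.

Working notes on the series. Compound 1 `C#C[C@]1(CO)O[C@@H](n2ccc(=O)[nH]c2=O)[C@H](O)[C@@H]1O` is the ethynyl parent, and compound 2 `N#C[C@]1(CO)O[C@@H](n2ccc(=O)[nH]c2=O)[C@H](O)[C@@H]1O` carries the change (cyano in place of ethynyl on a saturated ring carbon). In a functional assay on L1210 cells (Mus musculus) for cytotoxicity (on this read-out lower numbers stand for stronger inhibition and higher numbers for weaker inhibition), compound 1 gives only a limit, > 350000 nM. In this assay compound 2 likewise gives only a limit, > 350000 nM. The step that the two limits leave unreadable from compound 1 to compound 2 is therefore of no readable size. Compound 3 `C#C[C@]1(CO)O[C@@H](n2ccc(N)nc2=O)[C@H](O)[C@@H]1O` rests on a second core; the difference between the two cores is not broken down here. In this assay compound 3 also gives only a limit, > 350000 nM. Compound 4 `N#C[C@]1(CO)O[C@@H](n2ccc(N)nc2=O)[C@H](O)[C@@H]1O` carries the same change on the core of compound 3, (cyano in place of ethynyl on a saturated ring carbon), the two place descriptions agreeing word for word. Among the measured compounds shown here, every value so far sits at the limit (the limit of > 350000 nM in this assay, at which 3 of the 3 values shown sit), so no readable shift is tied to the change. For compound 4 the expected step is a step that the limit leaves unreadable from compound 3 to compound 4, resting on the unreadable a step that the two limits leave unreadable from compound 1 to compound 2. Compound 4 is estimated at 400000 nM in this assay, most probably again a limit.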

Compound 4, half-maximal inhibitory concentration: > 350000 nM
Compound 4 gave a limit, no number; the forecaster's own chance of this, stated with the estimate: 90%; the middle value does not contradict the limit.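

In this assay compound 3 and compound 4 both give only a limit, so no step between them can be read: the limit of > 350000 nM in this assay, at which 4 of the 4 values shown sit.
The compounds shown leave open whether cyano in place of ethynyl shifts this read-out at all on either core.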